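The compounds below may be only part of what the source reports. "The series", "measured", "known", "first", "only" and "open" are said of these compounds alone.

Measured so far in a functional assay on MCF7 cells (Homo sapiens) for cytotoxicity, read by CCK-8 assay, with a stated time of 24 h; a higher number here means a weaker inhibitor, a lower number a stronger inhibitor:

compound 1 `C/C(=C\c1nc(-c2ccccc2)cs1)C(N)=O`: 2380 nM
compound 2 `C/C(=C\c1nc(-c2ccc(C)cc2)cs1)C(N)=O`: a limit of this assay, > 50000 nM
compound 3 `C/C(=C\c1cccc(-c2ccccc2)c1)C(N)=O`: 6540 nM

Compound 2 sits at the limit of this assay (the limit of > 50000 nM in this assay, at which 1 of the 3 values shown sits), so only a bound is known for it. The change methyl in place of hydrogen on an aromatic carbon therefore produces an at least 21-fold higher number from compound 1 to compound 2 (1.32 log units; beyond the scatter). Compound 3 carries a different core; how it differs from the core of compound 1 is not broken down here, and in this assay compound 3 gives the higher of the two numbers.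

Compound 4 `C/C(=C\c1cccc(-c2ccc(C)cc2)c1)C(N)=O` is not yet measured. It differs from compound 3 by methyl in place of hydrogen on an aromatic carbon, the same change already made once in the series. A step of comparable direction and size is expected, a 7.6-fold higher number from compound 3 to compound 4 (0.88 log units; beyond the scatter), resting on an at least 21-fold higher number from compound 1 to compound 2 (1.32 log units; beyond the scatter). Compound 4 is thus estimated at 50000 nM, between 15000 nM and 200000 nM, and will likely be reported only as a limit.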

Compound 4, half-maximal inhibitory concentration: 6710 nM
Compound 4: middle estimate off by 7.5-fold (0.87 log units), on the high side, and the stated range ends above it.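

In this assay, methyl in place of hydrogen on an aromatic carbon gives a 1.0-fold higher number from compound 3 to compound 4 (0.01 log units; within the scatter), so the change does not carry over from one core to the other at the size seen earlier: the same change on two cores in this assay, an at least 21-fold higher number (1.32 log units; beyond the scatter) from compound 1 to compound 2 and a 1.0-fold higher number (0.01 log units; within the scatter) from compound 3 to compound 4, at least 20-fold (1.31 log units) apart, beyond the scatter of two such steps. Compound 2 is a limit of the assay, > 50000 nM, so the earlier step is known only as a bound. One pair on each core does not show why the cores differ, and it gives no rule for a third core.

Going by these compounds, it remains open whether a methoxy group, a chlorine or an amine at the same place would separate the two cores in the same way. On these data alone, whether the result on the core of compound 1 is particular to methyl also remains open.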